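Methoxy to hydroxy step on the shared core

This account rests on a few compounds, and the source may have more. Where it says the series, first, only, none or still open, it means among the compounds named here.

Measured so far in a functional assay on RPMI-8226 cells (Homo sapiens) for inhibition, read by sulforhodamine B assay, with a stated time of 48 h; on this read-out lower numbers stand for stronger inhibition of growth and higher numbers for weaker inhibition of growth:
compound 1 `O=C(Nc1cccc(-n2cc(-c3ccncc3)c(-c3ccc(Cl)c(O)c3)n2)c1)Nc1cccc(C(F)(F)F)c1`: 1340 nM
compound 2 `O=C(Nc1cccc(-n2cc(-c3ccncc3)c(-c3ccc(Cl)c(O)c3)n2)c1)Nc1ccc(Cl)c(Cl)c1`: 1030 nM
compound 3 `COc1cc(-c2nn(-c3cccc(NC(=O)Nc4ccc(Cl)c(C(F)(F)F)c4)c3)cc2-c2ccncc2)ccc1Cl`: 868 nM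

Among the compounds with values here, compound 3 holds the lowest of the three numbers, yet its gaps to compound 2 and compound 1 are both within the scatter, and the single one-point step, a 1.3-fold lower number from compound 1 to compound 2 (0.11 log units; within the scatter), is also within the scatter; none of the three is set apart. Compound 4 `O=C(Nc1cccc(-n2cc(-c3ccncc3)c(-c3ccc(Cl)c(O)c3)n2)c1)Nc1ccc(Cl)c(C(F)(F)F)c1` differs from compound 3 by hydrogen in place of methyl on an oxygen on an aromatic ring. Within the data shown here, no measured pair shows this change. Compound 1 and compound 2 carry the hydroxy already, and their numbers sit in the same range as compound 3. The step is therefore expected to be small, a 1.2-fold higher number from compound 3 to compound 4 (0.06 log units; within the scatter), with no direction beyond the scatter. Compound 4 is estimated at 1000 nM, with a range of 500 nM to 2000 nM.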

Compound 4, concentration for 50% growth inhibition: 580 nM
Compound 4: the middle estimate sits 1.7-fold (0.24 log units) above what was measured; the range from low to high includes it.
By their numbers in this assay, from the lowest: compounds 4, 3, 2 and 1 (each within the scatter of the next, the first and the last beyond it).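

In this assay, swapping methoxy for hydroxy gives a 1.5-fold lower number from compound 3 to compound 4 (0.18 log units; within the scatter), so this position does not separate the two groups. Within the data shown here, with the hydroxy held, trifluoromethyl in place of chloro on an aromatic carbon gives a 1.8-fold lower number from compound 2 to compound 4 (0.25 log units; within the scatter), whereas chloro in place of hydrogen on an aromatic carbon gives a 2.3-fold lower number from compound 1 to compound 4 (0.36 log units; beyond the scatter), the only modest step here that clears the scatter. No supporting data bear on why these steps take this size.

From the compounds shown here alone, whether an ethoxy group, or an amine in place of the hydroxy, would stay in the same range remains open.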